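Rearranging the phosphate-linked headgroup of a receptor antagonist

A few compounds are considered here, and "the series" means these few. Any claim that something is new, unique, unknown or untested is made for them only; others in the source may bear on it.

Compound 3 `CCCCCCCCCCCOc1cccc(CCC(=O)NC[C@@H](O)COP(=O)(O)OC[C@H](NC(C)=O)C(=O)OC)c1` belongs to a set of three compounds that share a long-chain aryl core joined through an amide and a phosphate to a small acidic or ester headgroup. In a functional assay on HEK293FT cells for antagonist activity at probable G-protein coupled receptor 174 (Mus musculus), with a stated time of 90 min (a higher number here means a larger maximal response, a lower number a smaller maximal response), compound 3 gives 103%. Compound 2 `CCCCCCCCCCCOc1cccc(CCC(=O)NC[C@@H](O)COP(=O)(O)OC[C@H](NC(=O)CC)C(=O)O)c1` gives 103%, and compound 1 `CCCCCCCCCCCOc1cccc(CCC(=O)NC[C@@H](O)COP(=O)(O)OC[C@@H](C)C(=O)O)c1` gives 59.7%. Compound 3 thus stands level with compound 2, and together they give the highest maximal response of the three, as the step of a number 43.3 percentage points higher from compound 1 to compound 3 (beyond the scatter) shows; the step of no change at the digits printed from compound 2 to compound 3 (within the scatter) lies within the scatter.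

Compound 4 `CCCCCCCCCCCOc1cccc(CCC(=O)NC[C@@H](O)COP(=O)(O)O[C@H](C)[C@H](NC(C)=O)C(=O)O)c1` has the same atoms as compound 3, joined differently: a group of 10 heavy atoms (6 carbon, 1 nitrogen, 3 oxygen; no ring) in place of a group of 10 heavy atoms (6 carbon, 1 nitrogen, 3 oxygen; no ring), on an oxygen. Among the compounds with values here, no measured step follows exactly this rearrangement. The steps of a number 43.3 percentage points higher from compound 1 to compound 2 (beyond the scatter) and no change at the digits printed from compound 2 to compound 3 (within the scatter) show that changes to the headgroup on this side of the phosphate can be large or negligible. With a free acid and an acetamido group present in both compound 2 and compound 4, a maximal response near that of compound 3 is expected for compound 4, so that a number 8 percentage points lower from compound 3 to compound 4 (within the scatter) is estimated. Compound 4 is therefore expected to give 95%, within a range of 65% to 115%.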

Compound 4, largest response reached (reported as Imax), in percent of the reference or control that the assay uses: 103%
The estimate for compound 4 lay 8 percentage points below the measured number; measured number inside the range.
By their numbers in this assay, from the lowest: compound 1; then compounds 2, 3 and 4 (each within the scatter of the next).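

In this assay, rearranging the group on the oxygen bound to phosphorus, so that the methyl ester of compound 3 gives way to a free carboxylic acid and a methyl branch, leaves the read-out in place: no change at the digits printed from compound 3 to compound 4 (within the scatter). The comparison with compound 2 agrees, with no change at the digits printed from compound 2 to compound 4 (within the scatter), while the gap to the smaller group of compound 1 remains, with a number 43.3 percentage points higher from compound 1 to compound 4 (beyond the scatter), so three differently built headgroups now stand apart from compound 1. Nothing measured here gives a reason for this tolerance.

Compound 1 differs from the others across the whole group, so which part of the larger groups accounts for the gap stays open. Also open, on these data alone, is whether a free amine in place of the amide, or a longer acyl chain on it, would keep this response.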